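The source may report more compounds than this note shows. Statements on the series, on what has been measured and on what is new or still open speak of the compounds shown alone.

Measured so far in an ADME assay on a cell-free system (plasma, Homo sapiens) for metabolic stability, read by LC-MS; on this read-out higher numbers stand for a longer-lived compound and lower numbers for a shorter-lived compound:
- compound 1 `CCCCOC(=O)c1cccc(-c2cc(C(=O)Nc3ccncc3)ccc2CN)c1` gives 0.367 h
- compound 2 `NCc1ccc(C(=O)Nc2ccncc2)cc1-c1cccc(C(=O)OCc2ccccc2)c1` gives 1.07 h

Compound 2 holds the higher number of the two (1.07 h). The next compound, compound 3 `CCCCCOC(=O)c1cccc(-c2cc(C(=O)Nc3ccncc3)ccc2CN)c1`, has not yet been measured. Its structure departs from that of compound 2 in one place (butyl in place of phenyl on a saturated chain carbon bound to an oxygen next to a carbonyl group), with butyl in place of phenyl on a saturated chain carbon bound to an oxygen next to a carbonyl group.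

Going by the values given here, only one measured step bears on this change (a 2.9-fold higher number from compound 1 to compound 2 (0.46 log units; beyond the scatter)). It was modest and beyond the scatter, with phenyl in place of propyl at that same place. The new change again swaps phenyl and a plain chain, but in the opposite direction, and butyl is not propyl. A single step is thin evidence, yet in this assay a drop of similar size is expected (a 2.7-fold lower number from compound 2 to compound 3 (0.43 log units; beyond the scatter)). The half-life of compound 3 is estimated at 0.4 h (expected range 0.17 h to 0.95 h).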

Compound 3, half-life: 0.967 h
Compound 3: the middle estimate sits 2.4-fold (0.38 log units) below what was measured; measured number above the stated range.
By their numbers in this assay, from the lowest: compound 1; then compounds 3 and 2 (each within the scatter of the next).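

In this assay, a ring at this place turns out not to be needed for a half-life in this range: with butyl in place of phenyl, the data show only a small shift that stays within the scatter (a 1.1-fold lower number from compound 2 to compound 3 (0.04 log units; within the scatter)). The length of the plain chain does matter, as going from propyl to butyl at the same place gives a clear step (a 2.6-fold higher number from compound 1 to compound 3 (0.42 log units; beyond the scatter)), similar in size to the earlier step from propyl to phenyl (a 2.9-fold higher number from compound 1 to compound 2 (0.46 log units; beyond the scatter)). Nothing measured here accounts for this difference between the two chains.

On these data alone, whether the trend with chain length continues to a longer chain such as hexyl remains open. So does the outcome with a branched chain such as isopropyl, or with an amine at the end of the chain.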